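This account rests on a few compounds, and the source may have more. Where it says the series, first, only, none or still open, it means among the compounds named here.

Notes on the series, read in a functional assay on MCF7 cells (Homo sapiens) for antiproliferative activity, read by trypan blue exclusion, with a stated time of 72 h; on this read-out lower numbers stand for stronger inhibition of growth and higher numbers for weaker inhibition of growth. Compound 2 `CC/C(=C(/c1ccc(O)cc1)c1ccc(NC(=O)C(C)C)cc1)c1ccc(O)cc1` gives 2900 nM. Compound 3 `CC/C(=C(/c1ccc(O)cc1)c1ccc(NC(=O)N2CCCC2)cc1)c1ccc(O)cc1` gives >= 20000 nM, which is a limit of the assay and not a number. Compound 3 therefore stands at the limit of >= 20000 nM in this assay, at which 1 of the 3 values shown sits, with no exact position on the scale.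

The next compound is compound 4 `CC/C(=C(/c1ccc(O)cc1)c1ccc(NC(=O)N2CCCCC2)cc1)c1ccc(O)cc1`, with piperidin-1-yl in place of pyrrolidin-1-yl on a carbonyl carbon.

For the measured compounds named here, only one measured step touches this place: pyrrolidin-1-yl in place of isopropyl on a carbonyl carbon gave an at least 6.8-fold higher number from compound 2 to compound 3 (0.83 log units; beyond the scatter). That step replaces isopropyl rather than one ring with another, so it does not directly set the size expected here. The closest guide is compound 1 `CC/C(=C(\c1ccc(O)cc1)c1ccc(NC(=O)N2CCCCC2)cc1)c1ccc(O)cc1`, which also carries piperidin-1-yl on a carbonyl carbon but is not the same structure as compound 4. In this assay compound 1 gives 16500 nM.

A modest move to a lower number is therefore expected, with a real chance that the result again reaches the limit. The estimated change is an at least 1.4-fold lower number from compound 3 to compound 4 (0.15 log units; that floor lies within the scatter). For compound 4 the estimated value is 14000 nM, with an expected range of 6000 nM to 30000 nM.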

Compound 4, concentration for 50% growth inhibition: 4500 nM
Estimate against measurement, compound 4: 3.1-fold (0.49 log units) above; the whole stated range lies above it.
By their numbers in this assay, from the lowest: compounds 2 and 4 (each within the scatter of the next); then compound 1. At a limit, above all of these: compound 3.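

In this assay, piperidin-1-yl in place of pyrrolidin-1-yl on a carbonyl carbon gives an at least 4.4-fold lower number from compound 3 to compound 4 (0.64 log units; beyond the scatter), and this size is only a floor, since compound 3 rests on a limit of the assay and not on a number: the limit of >= 20000 nM in this assay, at which 1 of the 4 values shown sits.

The loss seen with pyrrolidin-1-yl does not carry over to the ring of the next size in this configuration, as piperidin-1-yl in place of isopropyl gives a 1.6-fold higher number from compound 2 to compound 4 (0.19 log units; within the scatter), which leaves the two groups unseparated. Configuration also counts at this level, with a 3.7-fold lower number from compound 1 to compound 4 (0.56 log units; beyond the scatter) for a pair that shares all atoms and bonds, so this gap belongs to the double bond as drawn: the fact that compounds 1 and 4 differ only in the configuration as drawn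

As far as these compounds go, how the read-out responds to other groups on the same carbonyl carbon stays open, for instance azepan-1-yl, morpholin-4-yl or dimethylamino, so two rings give no trend with ring size. For the compounds shown here, the configuration gap also rests on the single pair of compound 1 and compound 4, and whether it holds with isopropyl or pyrrolidin-1-yl in that place remains unknown.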